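An Amino Group in Place of a Chloro

The compounds below may be only part of what the source reports. "The series", "measured", "known", "first", "only" and "open" are said of these compounds alone.

Compound 1 `ClCc1ccccc1Cn1cnc2c(Cl)nc(Cl)nc21` is the strongest growth inhibitor among the three measured compounds. In a functional assay on MOLT-4 cells (Homo sapiens) for cytotoxicity, read by sulforhodamine B assay, with a stated time of 48 h (a higher number here means a weaker inhibitor of growth, a lower number a stronger inhibitor of growth), compound 1 gives 200 nM. Compound 2 `ClCc1ccc(Cn2cnc3nc(Cl)nc(Cl)c32)cc1` gives 1380 nM in this assay, and compound 3 `ClCc1ccc(Cn2cnc3c(Cl)nc(Cl)nc32)cc1` gives 10500 nM; both gaps from compound 1 lie beyond the usual scatter. Compound 4 `Nc1nc(Cl)c2ncn(Cc3ccccc3CCl)c2n1` has not yet been measured. It differs from compound 1 in one place: amino in place of chloro on an aromatic carbon between two ring nitrogen atoms of the shared core. Going by the values given here, no measured pair shows this exact change, so the size of the step is open; a modest weakening is expected, with wide uncertainty. Compound 4 is estimated at 600 nM, within 150 nM to 2500 nM. The expected step from compound 1 to compound 4 is a 3.0-fold higher number from compound 1 to compound 4 (0.48 log units; beyond the scatter).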

Compound 4, concentration for 50% growth inhibition: 5130 nM
Estimate against measurement, compound 4: 8.6-fold (0.93 log units) below; the measured number lies above the stated range.
By their numbers in this assay, from the lowest: compound 1; then compound 2; then compound 4; then compound 3.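

The chloro on this aromatic carbon, between two ring nitrogen atoms of the shared core, turns out to matter greatly: amino in its place gives a 26-fold higher number from compound 1 to compound 4 (1.41 log units; beyond the scatter) in this assay. A swap of one heavy atom, which brings in a hydrogen-bond donor and a hydrogen-bond acceptor, is thus enough to lose most of the growth inhibition of compound 1. No measurement at hand explains the size of this step.

The compounds shown leave open how a methoxy or a dimethylamino group would fare at this position. Also open, on these data alone, is whether amino in place of chloro would cost as much on compound 2 or compound 3.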